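Halogen swap on the anilino ring of the shared core

The source may report more compounds than this note shows. Statements on the series, on what has been measured and on what is new or still open speak of the compounds shown alone.

Compound 1 `CC(C)c1ccc(-c2nc(SCc3cn(CC(=O)NC(=O)Nc4ccccn4)nn3)nc(Nc3ccccc3Cl)c2C#N)cc1` and compound 2 `CC(C)c1ccc(-c2nc(SCc3cn(CC(=O)NC(=O)Nc4ccccn4)nn3)nc(Nc3ccc(F)cc3)c2C#N)cc1` share one core; compound 2 carries a 4-fluorophenyl where compound 1 has a 2-chlorophenyl. In a functional assay on MGC-803 cells (Homo sapiens) for inhibition, read by MTT assay, with a stated time of 72 h (a lower number here means a stronger inhibitor, a higher number a weaker inhibitor), compound 1 gives 19700 nM and compound 2 gives 17500 nM, the lowest of the two numbers, its nearest neighbour being compound 1 at a 1.1-fold lower number from compound 1 to compound 2 (0.05 log units; within the scatter). Compound 3 `CC(C)c1ccc(-c2nc(SCc3cn(CC(=O)NC(=O)Nc4ccccn4)nn3)nc(Nc3ccc(Cl)cc3)c2C#N)cc1` brings (chloro in place of fluoro on an aromatic carbon), chloro in place of fluoro on an aromatic carbon, para to a large group. Going by the values given here, the single measured step, which changed both halogen and its place on the ring, lay within the scatter, so for this assay no step beyond the scatter is expected. Compound 3 is estimated at 15000 nM (7000 nM to 32000 nM). The expected step is a 1.2-fold lower number from compound 2 to compound 3 (0.07 log units; within the scatter).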

Compound 3, half-maximal inhibitory concentration: > 64000 nM
Compound 3 ended at the assay's limit; the forecaster's own chance of this, stated with the estimate: 5%; middle value at least 4.2-fold (0.63 log units) away from the limit.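

With a single heavy atom exchanged on the aromatic carbon, para to a large group, chloro in place of fluoro gives an at least 3.6-fold higher number from compound 2 to compound 3 (0.56 log units; beyond the scatter), so this ring is not indifferent to which halogen it carries. The place of the chlorine also counts: 4-chlorophenyl in place of 2-chlorophenyl gives an at least 3.2-fold higher number from compound 1 to compound 3 (0.51 log units; beyond the scatter), although the earlier halogen swap stayed within the scatter. The reading for compound 3 is a limit and not a number: the limit of > 64000 nM in this assay, at which 1 of the 3 values shown sits.

On these data alone, how far compound 3 lies past that limit remains open. Also open, as far as these compounds go, is whether bromo or methoxy at the same place would read like fluoro or like chloro.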